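The source may report more compounds than this note shows. Statements on the series, on what has been measured and on what is new or still open speak of the compounds shown alone.

Compound 1 `CCOC(=O)CCO/N=C(/c1ccc(OC)c(OC)c1OC)c1cccc2ccccc12`: 15200 nM in a functional assay on MDA-MB-231 cells (Homo sapiens) for inhibition, read by sulforhodamine B assay, with a stated time of 48 h; on this read-out lower numbers stand for stronger inhibition and higher numbers for weaker inhibition
Compound 2 `COc1cc(COC(c2ccc(OC)c(OC)c2OC)c2cccc3ccccc23)cc(OC)c1`: > 20000 nM in this assay

Going by the values given here, compound 1 holds the only numerical value in this assay. For compound 2 the reading is a limit, not a number, matching (the limit of > 20000 nM in this assay, at which 1 of the 2 values shown sits). Compound 3 `COc1ccc(/C(=N/OC(C)=O)c2cccc3ccccc23)c(OC)c1OC` differs from compound 1 by acetyl in place of 2-(ethoxycarbonyl)ethyl on an oxygen. Among the compounds with values here, no measured pair shows this change, so its step is expected to stay within the usual scatter, estimated at a 1.1-fold higher number from compound 1 to compound 3 (0.02 log units; within the scatter). Compound 3 is therefore expected to give 16000 nM, with a likely range from 5000 nM to 50000 nM.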

Compound 3, half-maximal inhibitory concentration: 17000 nM
Estimate against measurement, compound 3: 1.1-fold (0.03 log units) below, and the stated range covers the measured number.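

In this assay, acetyl in place of 2-(ethoxycarbonyl)ethyl on the oxygen whose other neighbour is the double-bonded nitrogen gives a 1.1-fold higher number from compound 1 to compound 3 (0.05 log units; within the scatter). Going by these compounds alone, this is the first step read at this position, and it shows that the smaller acetyl leaves the reading unchanged within the scatter, so the longer ester chain is not required for this level of inhibition. Nothing shown gives a cause for this result. Still open, on these data alone, is whether an amine or a carboxylic acid on this oxygen would move the reading beyond the scatter.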